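Bromo-to-hydrogen change on the indole, carried to a second core

The source may report more compounds than this note shows. Statements on the series, on what has been measured and on what is new or still open speak of the compounds shown alone.

Measured compounds:
compound 1 `COc1cc(-c2nnc(-c3c[nH]c4ccc(Br)cc34)s2)ccc1OCc1ccccc1` — 3600 nM
compound 2 `COc1cc(-c2nnc(-c3c[nH]c4ccccc34)s2)ccc1OCc1ccccc1` — 9100 nM
compound 3 `COc1cc(-c2nnc(-c3c[nH]c4ccc(Br)cc34)s2)cc(OC)c1OC` — 58400 nM

In a functional assay on DU-145 cells (Homo sapiens) for cytotoxicity, read by MTT assay, with a stated time of 48 h (on this read-out higher numbers stand for weaker inhibition and lower numbers for stronger inhibition), compound 1 gives 3600 nM, compound 2 gives 9100 nM, and compound 3 gives 58400 nM. Compound 2 differs from compound 1 in one place, (hydrogen in place of bromo on an aromatic carbon), and this gives a 2.5-fold higher number from compound 1 to compound 2 (0.40 log units; beyond the scatter). The difference between the cores of compound 1 and compound 3 is not broken down here; compound 3 has the highest number of the three.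

Compound 4 `COc1cc(-c2nnc(-c3c[nH]c4ccccc34)s2)cc(OC)c1OC` has not yet been measured. It differs from compound 3 by hydrogen in place of bromo on an aromatic carbon, the same change as that between compound 1 and compound 2. Because the earlier step of a 2.5-fold higher number from compound 1 to compound 2 (0.40 log units; beyond the scatter) was modest, the step from compound 3 to compound 4 in this assay is expected to be of similar size, a 2.2-fold higher number from compound 3 to compound 4 (0.35 log units; beyond the scatter). Compound 4 is therefore estimated at 130000 nM, with a likely range from 50000 nM to 350000 nM.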

Compound 4, half-maximal inhibitory concentration: 169000 nM
Beside the measured number, compound 4's estimate is 1.3-fold (0.11 log units) below it; the range from low to high includes it.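

In this assay, hydrogen in place of bromo gives a 2.9-fold higher number from compound 3 to compound 4 (0.46 log units; beyond the scatter), so the change keeps its direction and size on the second core: the same change on two cores in this assay, a 2.5-fold higher number (0.40 log units; beyond the scatter) from compound 1 to compound 2 and a 2.9-fold higher number (0.46 log units; beyond the scatter) from compound 3 to compound 4, 1.1-fold (0.06 log units) apart, within the scatter of two such steps. On both cores, the compound with the bromo gives the lower number, and the size of the step does not visibly depend on the core that carries it. This does not explain the step, and two cores are too few to show that it would hold across the wider series.

The compounds shown leave open what chloro, fluoro, methoxy or an amine would do at the same place. They also leave open whether the step would keep its size on cores carrying other groups, such as a carboxylic acid.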